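Furan-2-yl for furan-3-yl on a shared nucleoside core

A few compounds are considered here, and "the series" means these few. Any claim that something is new, unique, unknown or untested is made for them only; others in the source may bear on it.

Measured compounds:
Compound 1, `Cc1nc(N)c2c(-c3ccco3)cn([C@@H]3O[C@H](CO)[C@@H](O)[C@H]3O)c2n1`: > 100000 nM
Compound 2, `COc1nc(N)nc2c1c(-c1ccoc1)cn2[C@@H]1O[C@H](CO)[C@@H](O)[C@H]1O`: > 100000 nM
Compound 3, `Cc1nc(N)c2c(-c3ccoc3)cn([C@@H]3O[C@H](CO)[C@@H](O)[C@H]3O)c2n1`: > 100000 nM

Of the compounds shown here, three have been tested in an ADME assay on MRC5 cells (Homo sapiens), read by MTT assay, with a stated time of 72 h; on this read-out higher numbers stand for weaker inhibition and lower numbers for stronger inhibition. In this assay compound 1 reaches only the limit of > 100000 nM, which is a limit of the assay and not a number. Compound 2 likewise gives > 100000 nM, again a limit. Compound 3 gives > 100000 nM, also a limit.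

Compound 3 and compound 1 differ in one place, (furan-2-yl in place of furan-3-yl on an aromatic carbon). The step that the two limits leave unreadable from compound 3 to compound 1 cannot be read, since both values sit at the limit. The cores of compound 2 and compound 3 differ in more than one place; that difference is not broken down here.

Compound 4, `COc1nc(N)nc2c1c(-c1ccco1)cn2[C@@H]1O[C@H](CO)[C@@H](O)[C@H]1O`, has not yet been measured in this assay. It differs from compound 2 by furan-2-yl in place of furan-3-yl on an aromatic carbon, the same change as that from compound 3 to compound 1, made at a place described in identical words. Because (the limit of > 100000 nM in this assay, at which 3 of the 3 values shown sit), the expected step that the limit leaves unreadable from compound 2 to compound 4 from compound 2 to compound 4 cannot be given as a read size, and it is expected that compound 4 will also sit at the limit. The estimate for compound 4 in this assay is 150000 nM, with an expected range from 80000 nM to 500000 nM, resting on the limits returned by compound 1, compound 2 and compound 3.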

Compound 4, half-maximal inhibitory concentration: 89700 nM
Compound 4: middle estimate off by 1.7-fold (0.22 log units), on the high side, and the stated range covers the measured number.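

In this assay, furan-2-yl in place of furan-3-yl on an aromatic carbon gives an at least 1.1-fold lower number from compound 2 to compound 4 (0.04 log units; that floor lies within the scatter), and this printed size is only a floor, as the starting value is a limit of the assay and not a number. As far as these compounds go, the same change from compound 3 to compound 1 cannot be read, because both of those values are limits, as are most of the values in this small set: the limit of > 100000 nM in this assay, at which 3 of the 4 values shown sit. What this shows is narrow: on one core the change ends at a measured number, while the starting point stays a limit, so the true size of the step is unknown and the floor alone does not establish a real change; nothing here shows whether the change carries over to the other core, or that it does not.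

The compounds shown leave open whether the same change would give a readable step on the other core, where compound 1 and compound 3 offer only limits. They also leave open how this assay would read with a phenyl group, a thiophene or an amine on the same aromatic carbon in place of either furan.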